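Bromo for Methyl in a Cytotoxicity Series

The source may hold more compounds than are shown below. What is called first, only, known or untested is meant among the compounds shown, and "the series" means these compounds.

Measured compounds:
compound 1, `Cc1ccccc1Sc1cccc(N)c1C#N`: > 40000 nM
compound 2, `N#Cc1c(N)cccc1Sc1ccccc1Br`: 41000 nM
compound 3, `Cc1ccccc1[S+]([O-])c1cccc(N)c1C#N`: > 200000 nM

In a functional assay on MT4 cells (Homo sapiens) for cytotoxicity (a lower number here means a stronger inhibitor, a higher number a weaker inhibitor), compound 1 reaches only a limit of the assay, > 40000 nM. In this assay compound 2 gives 41000 nM. Compound 3 likewise reaches only a limit, > 200000 nM. The change from compound 1 to compound 2 is bromo in place of methyl on an aromatic carbon, and the step it made is a step that the limit leaves unreadable from compound 1 to compound 2, since one of the two values sits at the limit of > 40000 nM in this assay, at which 1 of the 3 values shown sits. The difference between the cores of compound 1 and compound 3 is not broken down here. Compound 4, `N#Cc1c(N)cccc1[S+]([O-])c1ccccc1Br`, carries the same change on the core of compound 3: bromo in place of methyl on an aromatic carbon. With compound 3 sitting at the limit of > 200000 nM in this assay, at which 1 of the 3 values shown sits, the step from compound 1 to compound 2 gives no readable size to lean on, so the expectation for compound 4 rests mainly on the limit of compound 3. The step from compound 3 to compound 4 is expected to be a step that the limit leaves unreadable from compound 3 to compound 4. Compound 4 is therefore estimated at 250000 nM, with a range from 60000 nM to 1000000 nM, and most likely again only a limit.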

Compound 4, half-maximal inhibitory concentration: 168000 nM
Compound 4: the middle estimate sits 1.5-fold (0.17 log units) above what was measured; the measured number falls inside the stated range.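

In this assay, bromo in place of methyl on an aromatic carbon gives an at least 1.1-fold lower number from compound 3 to compound 4 (0.07 log units; that floor lies within the scatter). Compound 3 sits at a limit of the assay, > 200000 nM. The step is therefore only a floor, not a true size, and the matching step on the core of compound 1 cannot be read, so whether the change has the same size on both cores remains unshown.

The compounds shown leave open what other groups on this aromatic carbon, such as chloro, methoxy or an amine, would do to the number in this assay. As far as these compounds go, it also remains open whether a carboxylic acid there would give a step beyond the usual scatter.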